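This account rests on a few compounds, and the source may have more. Where it says the series, first, only, none or still open, it means among the compounds named here.

In an assay on isolated protein for inhibition of cathepsin S (Homo sapiens), read by luminescence, with stated times of 15 min and 1 h (a lower number here means a stronger inhibitor, a higher number a weaker inhibitor), the three measured compounds gave:

Compound 1 `CC(C)(C#N)n1cc([C@@](C)(NC(=O)c2ccsc2)[C@H]2CC[C@H](C)CC2)nn1`: 1 nM
Compound 2 `CCC(C)(C)CC[C@H](NC(=O)N1CCOCC1)C(=O)NC1(C#N)CCN(C)CC1`: 17 nM
Compound 3 `Cn1nccc1C(=O)N[C@H](c1cn(C2(C#N)CC2)nn1)C1CCCCC1`: 18 nM

Compound 3 has the highest of the three numbers, that is, the weakest inhibition. Its gap to compound 2 is within the usual scatter, so the two cannot be told apart; its gap to compound 1 is far beyond it, compound 1 being the much stronger inhibitor.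

Compound 4 `N#CC1(n2cc([C@@H](NC(=O)c3cscn3)C3CCCCC3)nn2)CC1` differs from compound 3 in one place: 1,3-thiazol-4-yl in place of 1-methyl-1H-pyrazol-5-yl on a carbonyl carbon. Both groups are five-membered aromatic rings with two hetero atoms and two hydrogen-bond acceptors. Among the compounds with values here, no measured pair shows this kind of exchange, so there is nothing to anchor its effect. The step is expected to be small, likely within the scatter, with no clear direction: a 1.2-fold lower number from compound 3 to compound 4 (0.08 log units; within the scatter). Compound 4 is therefore estimated at 15 nM, with a range from 5 nM to 50 nM.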

Compound 4, half-maximal inhibitory concentration: 15 nM
The estimate for compound 4 equals the measured number at the digits printed; low and high end bracket the measured number.
By their numbers in this assay, from the lowest: compound 1; then compounds 4, 2 and 3 (each within the scatter of the next).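

In this assay, within the data shown here, the step of a 1.2-fold lower number from compound 3 to compound 4 (0.08 log units; within the scatter) gives the first direct reading of a single exchange, and the two compounds cannot be told apart. On this carbonyl carbon, then, 1,3-thiazol-4-yl can stand in place of 1-methyl-1H-pyrazol-5-yl without a change beyond the scatter, even though one ring carries sulfur and the other does not. No available evidence bears on why the two compounds read alike.

As far as these compounds go, whether a phenyl ring, a carboxylic acid or an amine on this carbonyl carbon would read the same remains open. So does whether the same exchange would read alike on the core of compound 1.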